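Fluoro to hydroxy on compound 3

The compounds below may be only part of what the source reports. "The series", "measured", "known", "first", "only" and "open" are said of these compounds alone.

Measured in a functional assay on COLO 205 cells (Homo sapiens) for inhibition, read by sulforhodamine B assay; a higher number here means a weaker inhibitor of growth, a lower number a stronger inhibitor of growth:
- compound 1 `COc1ccc(-c2ccc(-c3ccc(-c4nc5cc(C)ccc5[nH]4)cc3)cc2)cc1OC`: 2320 nM
- compound 2 `COc1cc(-c2ccc(-c3ccc(-c4nc5cc(C)ccc5[nH]4)cc3)cc2)cc(OC)c1OC`: 190 nM
- compound 3 `Fc1ccc(-c2ccc(-c3ccc(-c4nc5ccccc5[nH]4)cc3)cc2)cc1`: 100000 nM

Compound 3 has the highest number of the three, beyond the scatter from both others. Compound 4 `Oc1ccc(-c2ccc(-c3ccc(-c4nc5ccccc5[nH]4)cc3)cc2)cc1` carries hydroxy in place of fluoro on an aromatic carbon, para to a large group: hydroxy in place of fluoro on an aromatic carbon. Among the measured compounds shown here, no measured step makes this exact change. The nearest evidence is a large step for methoxy in place of hydrogen, a 12-fold lower number from compound 1 to compound 2 (1.09 log units; beyond the scatter), which bears only indirectly, as it shows that one substituent change can move the number widely in this assay. A step of similar size toward a lower number is therefore expected, with wide uncertainty. The expected step is a 5.0-fold lower number from compound 3 to compound 4 (0.70 log units; beyond the scatter). Compound 4 is estimated at 20000 nM, within a range of 3000 nM to 100000 nM.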

Compound 4, concentration for 50% growth inhibition: 100000 nM
Compound 4: the middle estimate sits 5.0-fold (0.70 log units) below what was measured, within the range that was stated.
By their numbers in this assay, from the lowest: compound 2; then compound 1; then compounds 3 and 4 (each within the scatter of the next).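

In this assay, 4-fluorophenyl to 4-hydroxyphenyl gives no change at the digits printed from compound 3 to compound 4 (within the scatter), so on the core of compound 3 this exchange at this position leaves the number where it was. Adding a hydrogen-bond donor and a hydrogen-bond acceptor here therefore brings no reading of growth inhibition that differs from the fluoro compound, in contrast to the wide methoxy step a 12-fold lower number from compound 1 to compound 2 (1.09 log units; beyond the scatter) on the core of compound 1. No measurement here accounts for the absence of a change.
Open, as far as these compounds go, is whether an amine or a carboxylic acid at this position would move the number on this core. Also open, from the compounds shown here alone, is whether hydroxy in place of fluoro would behave the same way on the core of compound 2.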